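The source may hold more compounds than are shown below. What is called first, only, known or untested is meant among the compounds shown, and "the series" means these compounds.

Of the compounds shown here, three sharing one core have been measured in a functional assay on A-375 cells (Homo sapiens) for inhibition, read by CCK-8 assay, with a stated time of 72 h, tested at 2 uM; on this read-out lower numbers stand for less inhibition of growth and higher numbers for more inhibition of growth at the one concentration tested. Compound 1 `COc1ccc(SCc2ccc(/C=C/C(=O)Nc3ccccc3N)cc2)cc1OC` gives 46%. Compound 2 `Nc1ccccc1NC(=O)c1ccc(CSc2ccc(Br)cc2)cc1` gives 4.35%, the second highest of the three numbers, sitting within the usual scatter of compound 3 `Nc1ccccc1NC(=O)c1ccc(CSc2ccc(C(F)(F)F)cn2)cc1`, which gives 4.3%, and well below compound 1. Compound 4 `Cc1ccc(SCc2ccc(C(=O)Nc3ccccc3N)cc2)cc1` has not yet been measured. It differs from compound 2 in one place: methyl in place of bromo on an aromatic carbon. Going by the values given here, no two measured compounds differ in only one place, so no measured step shows what such a change does here. Compound 2 with 4.35% and compound 3 with 4.3% lie together although their outer groups differ, which suggests a step in this assay of no more than the scatter, in either direction. Compound 4 is therefore expected to give 5%, between 0% and 18%. The expected step is a number 0.7 percentage points higher from compound 2 to compound 4 (within the scatter).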

Compound 4, percent growth inhibition at one concentration: 17.5%
Compound 4: the middle estimate sits 12.5 percentage points below what was measured, and the stated range covers the measured number.
By their numbers in this assay, from the lowest: compounds 3 and 2 (each within the scatter of the next); then compound 4; then compound 1.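

In this assay, methyl in place of bromo on this aromatic carbon gives a number 13.2 percentage points higher from compound 2 to compound 4 (beyond the scatter), a modest change from swapping one heavy atom for another. Going by these compounds alone, no earlier pair isolated a single change, so this is the first sign that the group at this position of the 4-substituted phenyl ring can alter growth inhibition beyond the scatter. No measurement shown gives a reason for this step. As far as these compounds go, whether an amine or a carboxylic acid at this position would raise or lower inhibition remains open. So does whether the same change would have a similar effect on the core of compound 1.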